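The source may hold more compounds than are shown below. What is called first, only, known or untested is meant among the compounds shown, and "the series" means these compounds.

Measured in an ADME assay on a cell-free system (plasma, Homo sapiens) for protein binding, read by LC-MS, using ultracentrifugation, tested at 5 uM (on this read-out higher numbers stand for a larger free fraction and lower numbers for a smaller free fraction), so far
compound 1 `C[C@H](Nc1ncnc(N)c1C#N)c1nc2ccc(F)cc2n1-c1ccc(F)cc1` gives 0.11
compound 2 `C[C@H](Nc1ncnc(N)c1C#N)c1nc2ccc(F)cc2n1-c1cc(F)cc(F)c1` gives 0.12
compound 3 `C[C@H](Nc1ncnc(N)c1C#N)c1nc2ccc(F)cc2n1-c1ccccc1` gives 0.07

Compound 3 stands within the scatter of compound 1 and compound 2, the two steps to it being a 1.6-fold lower number from compound 1 to compound 3 (0.20 log units; within the scatter) and a 1.7-fold lower number from compound 2 to compound 3 (0.23 log units; within the scatter). Next comes compound 4 `C[C@H](Nc1ncnc(N)c1C#N)c1nc2ccc(F)cc2n1-c1ccccn1`, with pyridin-2-yl in place of phenyl on an aromatic nitrogen. The steps bearing on this place are the swaps of the group on that nitrogen, a 1.1-fold higher number from compound 1 to compound 2 (0.04 log units; within the scatter) and the two above, none beyond the scatter. From the compounds shown here alone, none of them brings a hetero atom into that ring, so the change itself is untested. In this assay no step beyond the scatter is therefore expected. The expected step is a 1.4-fold higher number from compound 3 to compound 4 (0.15 log units; within the scatter). Compound 4 is estimated at 0.1, with an expected range from 0.06 to 0.17.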

Compound 4, unbound fraction: 0.27
For compound 4 the middle estimate is 2.7-fold (0.43 log units) below the measured one; the measured number lies above the stated range.
By their numbers in this assay, from the lowest: compounds 3, 1 and 2 (each within the scatter of the next); then compound 4.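

Pyridin-2-yl on the aromatic nitrogen gives the first steps beyond the scatter in this assay: a 3.9-fold higher number from compound 3 to compound 4 (0.59 log units; beyond the scatter), a 2.5-fold higher number from compound 1 to compound 4 (0.39 log units; beyond the scatter) and a 2.3-fold higher number from compound 2 to compound 4 (0.35 log units; beyond the scatter). Among compounds 1, 2 and 3, the carbon-only rings stayed within the scatter of one another, so a ring with a hetero atom and a hydrogen-bond acceptor is what sets compound 4 apart at this place. No measured evidence accounts for the rise.

From the compounds shown here alone, whether pyridin-3-yl or pyrimidin-2-yl on that nitrogen would give a similar free fraction remains open. So does whether fluoro on the pyridin-2-yl ring would keep it.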